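Cyclopropyl in Place of an Ester Side Chain

The compounds below may be only part of what the source reports. "The series", "measured", "known", "first", "only" and "open" are said of these compounds alone.

Compound 1 `CC[C@H](NC(=O)/C(C#N)=C/c1cccc(Br)n1)c1ccccc1`: 1100 nM
Compound 2 `COC(=O)C[C@H](NC(=O)/C(C#N)=C/c1cccc(Br)n1)c1ccccc1`: 3100 nM

Going by the values given here, in a functional assay on MM1 cells (Homo sapiens) for antiproliferative activity, read by MTT assay, with a stated time of 72 h (a lower number here means a stronger inhibitor, a higher number a weaker inhibitor), compound 2 gives 3100 nM, the highest of the two numbers measured so far; the only neighbour, compound 1, gives 1100 nM. Compound 3 `N#C/C(=C\c1cccc(Br)n1)C(=O)N[C@H](c1ccccc1)C1CC1` differs from compound 2 in one place: cyclopropyl in place of (methoxycarbonyl)methyl on a saturated chain carbon bound to an amide-type nitrogen and an aromatic carbon. Among the compounds with values here, the single measured step that bears on this is a 2.8-fold higher number from compound 1 to compound 2 (0.45 log units; beyond the scatter). Taking the methoxycarbonyl away again is expected to undo most of that change, so a lower number is expected for compound 3. The estimate for compound 3 is 1000 nM, within a range of 400 nM to 2500 nM, corresponding to an expected step of a 3.1-fold lower number from compound 2 to compound 3 (0.49 log units; beyond the scatter).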

Compound 3, half-maximal inhibitory concentration: 1400 nM
The estimate for compound 3 lay 1.4-fold (0.15 log units) below the measured number, within the range that was stated.
By their numbers in this assay, from the lowest: compounds 1 and 3 (each within the scatter of the next); then compound 2.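

In this assay the new compound shows that this saturated chain carbon tolerates a ring as well as an open chain: cyclopropyl in place of (methoxycarbonyl)methyl gives (a 2.2-fold lower number from compound 2 to compound 3 (0.35 log units; beyond the scatter)), whereas cyclopropyl in place of ethyl gives (a 1.3-fold higher number from compound 1 to compound 3 (0.10 log units; within the scatter)). Among these three compounds, only the ester-bearing compound 2 stands apart. Nothing measured here accounts for that difference.

As far as these compounds go, it remains open how a carboxylic acid, an amine or a longer chain on this carbon would read. Larger carbocycles, such as cyclohexyl, are equally open.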